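A few compounds are considered here, and "the series" means these few. Any claim that something is new, unique, unknown or untested is made for them only; others in the source may bear on it.

Measured in a functional assay on MCF7 cells (Homo sapiens) for antiproliferative activity, read by MTT assay, with a stated time of 72 h; a lower number here means a stronger inhibitor, a higher number a weaker inhibitor:
- compound 1 `CC(C)N1C(=O)COc2ccc(-c3cnc(Cl)c(NS(=O)(=O)c4ccc(F)cc4)c3)cc21`: 26600 nM
- compound 2 `COc1ncc(-c2ccc3c(c2)N(c2ccccc2)C(=O)CO3)cc1NS(=O)(=O)c1ccc(F)cc1`: 8870 nM

Among the measured compounds shown here, only two numbers are available so far, and both are high, so these are weak inhibitors of cell growth. Compound 2, at 8870 nM, has the lower number of the two, and its gap to compound 1 lies beyond the usual scatter of repeated measurements. The two compounds differ in more than one place, so their gap cannot be pinned on any single group.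

The next compound is compound 3 `COc1ncc(-c2ccc3c(c2)N(C(C)C)C(=O)CO3)cc1NS(=O)(=O)c1ccc(F)cc1`. It keeps the rest of compound 2 and makes one change: isopropyl in place of phenyl on an amide-type nitrogen in a ring.

For the measured compounds named here, no measured pair shows this change alone, so the data give no direct size for it. In this assay, the expectation is therefore no step beyond the scatter, and compound 2 at 8870 nM serves as the starting point. The expected result is a 1.5-fold lower number from compound 2 to compound 3 (0.17 log units; within the scatter), an estimate that carries real uncertainty in either direction. For compound 3 the estimated value is 6000 nM, with an expected range from 1500 nM to 24000 nM.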

Compound 3, half-maximal inhibitory concentration: 17000 nM
Estimate against measurement, compound 3: 2.8-fold (0.45 log units) below; low and high end bracket the measured number.
By their numbers in this assay, from the lowest: compounds 2, 3 and 1 (each within the scatter of the next, the first and the last beyond it).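

In this assay, isopropyl in place of phenyl on the amide-type nitrogen gives a 1.9-fold higher number from compound 2 to compound 3 (0.28 log units; within the scatter), so this position accepts a group with no ring and fewer heavy atoms without a step beyond the scatter, at least for these two groups. Compound 3 also provides a second single-place comparison, as methoxy in place of chloro on an aromatic carbon gives a 1.6-fold lower number from compound 1 to compound 3 (0.19 log units; within the scatter), which means that neither change, taken alone, produces a step larger than repeated measurements can show. No measured property of these groups is available to explain either step.

Phenyl and isopropyl are only two possibilities on the amide-type nitrogen, so it remains open whether a different group there, such as a longer chain ending in an amine or one bearing a carboxylic acid, would give a clear step. The same question applies to the aromatic carbon that carries chloro or methoxy, where a group such as nitrile or trifluoromethyl has yet to be compared in this series.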